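Methylamino for butoxy: cytotoxicity outlook for compound 4

The compounds below may be only part of what the source reports. "The series", "measured", "known", "first", "only" and "open" are said of these compounds alone.

Three compounds share one core carrying an amino group and a branched diol side chain. In an ADME assay on MOLT-3 cells (Homo sapiens) for cytotoxicity, with a stated time of 7 days (on this read-out lower numbers stand for higher toxicity in this test and higher numbers for lower toxicity in this test), compound 1 `Nc1nc(NC2CCCCC2)c2ncn(/C=C3/CC3(CO)CO)c2n1` gives "not determined" (no result reported). In this assay compound 2 `CC(C)Nc1nc(N)nc2c1ncn2/C=C1/CC1(CO)CO` gives "not determined" (no result reported). Compound 3 `CCCCOc1nc(N)nc2c1ncn2/C=C1/CC1(CO)CO` is the only one with a result. In this assay compound 3 gives > 20000 nM, a limit of the assay and not a number. Among the values shown, compound 3 therefore stands at the limit of > 20000 nM in this assay, at which 1 of the 3 values shown sits. The untested compound 4 `CNc1nc(N)nc2c1ncn2/C=C1/CC1(CO)CO` differs from compound 3 by methylamino in place of butoxy on an aromatic carbon. With no step between measured compounds shown, nothing indicates a shift beyond the scatter in this assay in either direction. The expected step is a step that the limit leaves unreadable from compound 3 to compound 4. Compound 4 is estimated at 25000 nM, with a range from 8000 nM to 80000 nM.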

Compound 4, half-maximal cytotoxic concentration: > 20000 nM
Compound 4 ended at the assay's limit; the forecaster's own chance of this, stated with the estimate: 75%; the middle value is on the limit's open side.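

Compound 3 and compound 4 both end at a limit of the assay, not a number, so no step can be read between them: the limit of > 20000 nM in this assay, at which 2 of the 4 values shown sit.

The compounds shown leave open how far methylamino and butoxy differ in this assay, and what value lies behind either limit.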